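Adding a Nitro Group to the Ring System of Compound 2

The source may report more compounds than this note shows. Statements on the series, on what has been measured and on what is new or still open speak of the compounds shown alone.

Measured compounds:
Compound 1, `O=C(Sc1ccc(Br)cc1)c1cc2ccccc2oc1=O`: in an assay on isolated protein for inhibition of Amine oxidase [flavin-containing] A (Homo sapiens), read by fluorescence (a lower number here means a stronger inhibitor, a higher number a weaker inhibitor), compound 1 gives 22700 nM.
Compound 2, `O=C(SCc1ccco1)c1cc2ccccc2oc1=O`: in this assay compound 2 gives 39700 nM.

Compound 2 stands at the highest of the two numbers measured, its nearest neighbour being compound 1, and the step of a 1.7-fold higher number from compound 1 to compound 2 (0.24 log units; within the scatter) lies within the scatter. Compound 3, `O=C(SCc1ccco1)c1cc2cc([N+](=O)[O-])ccc2oc1=O`, differs from compound 2 by nitro in place of hydrogen on an aromatic carbon. Going by the values given here, no measured step touches this position: the only step available, a 1.7-fold higher number from compound 1 to compound 2 (0.24 log units; within the scatter), concerns the group on the sulfur and was itself within the scatter. There is therefore no basis in the data for a direction, and the expectation is a step no larger than the scatter. The account estimates for compound 3 a step of a 1.1-fold lower number from compound 2 to compound 3 (0.05 log units; within the scatter), that is a value of 35000 nM, expected to fall between 12000 nM and 100000 nM.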

Compound 3, half-maximal inhibitory concentration: 48300 nM
Beside the measured number, compound 3's estimate is 1.4-fold (0.14 log units) below it, and the stated range covers the measured number.
By their numbers in this assay, from the lowest: compounds 1, 2 and 3 (each within the scatter of the next, the first and the last beyond it).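

In this assay, the step of a 1.2-fold higher number from compound 2 to compound 3 (0.09 log units; within the scatter) shows that a nitro group on an aromatic carbon, part of a fused system of two rings, gives no change that can be told from the scatter. Going by these compounds alone, the earlier compounds spoke only to the group on the sulfur, whereas compound 3 is the first to show a change on the shared core itself, and the number stays within the scatter of compound 2. Nothing at hand explains this result.

As far as these compounds go, whether an amine or a methoxy group on the same carbon would also stay within the scatter remains open. So does whether nitro would give a similar step with the 4-bromophenyl group of compound 1 on the sulfur.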